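A few compounds are considered here, and "the series" means these few. Any claim that something is new, unique, unknown or untested is made for them only; others in the source may bear on it.

Measured so far:
- compound 1 `COc1ccccc1N1CCN(CCCNC(=O)NN(Cc2ccc(F)cc2)c2ccc(F)cc2)CC1`, in an assay on CHO cells for displacement of a labelled ligand from D(4) dopamine receptor (Homo sapiens), read by radioligand binding (a higher number here means a weaker inhibitor, a lower number a stronger inhibitor), compound 1 gives 4.6 nM
- compound 2 `COc1ccc(N(Cc2ccccc2F)NC(=O)NCCCN2CCN(c3ccccc3OC)CC2)cc1`, in this assay compound 2 gives 2.6 nM

Two compounds of the series have a number. Compound 2 holds the lowest of the two numbers in this assay, and its nearest neighbour is compound 1, whose number lies within the scatter of compound 2. Among the measured compounds shown here, no step between measured compounds that differ in one place is available, so the two values say only that both compounds sit close together and that neither can be called stronger than the other.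

Compound 3 `COc1ccc(N(Cc2ccc(F)cc2)NC(=O)NCCCN2CCN(c3ccccc3OC)CC2)cc1` is not yet measured. It is derived from compound 2 by one rearrangement: 4-fluorophenyl in place of 2-fluorophenyl on a saturated chain carbon bound to a nitrogen on an aromatic ring. The rest of the molecule is unchanged. Nothing in the measured pair isolates the position of the fluorine on the benzyl group, so no direction can be read from the data. The expectation is a step from compound 2 to compound 3 of no size beyond the scatter, a 1.2-fold higher number from compound 2 to compound 3 (0.06 log units; within the scatter), in this assay. Compound 3 is accordingly estimated at 3 nM, with a range from 1.3 nM to 8 nM.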

Compound 3, inhibition constant: 2.9 nM
Compound 3: middle estimate off by 1.0-fold (0.01 log units), on the high side, within the range that was stated.
By their numbers in this assay, from the lowest: compounds 2, 3 and 1 (each within the scatter of the next).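

In this assay, among the compounds shown here, exchanging 2-fluorobenzyl for 4-fluorobenzyl gives a 1.1-fold higher number from compound 2 to compound 3 (0.05 log units; within the scatter) and is the first direct reading at this place, on a saturated chain carbon bound to a nitrogen on an aromatic ring: within this pair, the two fluorophenyl isomers cannot be told apart. The second one-place exchange, methoxy in place of fluoro on an aromatic carbon with the 4-fluorobenzyl group held constant, gives a 1.6-fold lower number from compound 1 to compound 3 (0.20 log units; within the scatter) and likewise separates neither compound from the other, so neither of the two exchanges shown moves the number beyond the scatter in this assay. No measurement is available that bears on why these values lie so close together.

Whether the benzyl place accepts larger departures remains open, since the compounds shown carry only a fluorine there and say nothing about an unsubstituted benzyl, a 3-fluorobenzyl, a trifluoromethyl group or a carboxylic acid on that ring. Also open, from the compounds shown here alone, is whether methoxy and fluoro would remain indistinguishable beside other benzyl groups, and how a longer chain in the shared core would read in this assay when set against compound 3 at 2.9 nM as the reference.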